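The source may report more compounds than this note shows. Statements on the series, on what has been measured and on what is new or still open speak of the compounds shown alone.

Measured in a functional assay on the whole organism with Rattus norvegicus as the target; on this read-out higher numbers stand for an effect only at larger amounts of compound and lower numbers for an effect already at smaller amounts:
Compound 1 `CN(C)C(=O)/C=C1\CCc2ccc(F)cc21` gives 16 mg/kg
Compound 2 `O=C(/C=C1\CCc2ccc(F)cc21)NCc1ccccc1` gives 16 mg/kg
Compound 3 `O=C(/C=C1\CCc2ccc(F)cc21)Nc1ccccc1` gives 8 mg/kg

Compound 3 , at 8 mg/kg, lies within the usual scatter of both compound 1 and compound 2, so these three cannot be ranked. The next compound is compound 4 `NC(=O)/C=C1\CCc2ccc(F)cc21`, which has hydrogen in place of phenyl on an amide-type nitrogen. For the measured compounds named here, one measured step bears on this, the swap of benzyl for phenyl on that same nitrogen: a 2.0-fold lower number from compound 2 to compound 3 (0.30 log units; within the scatter). Going by the values given here, no measured compound carries hydrogen there, so the range must stay wide. In this assay, the expected change is small and stays within the scatter: a 1.5-fold higher number from compound 3 to compound 4 (0.18 log units; within the scatter). Compound 4 is estimated at 12 mg/kg, with an expected range from 5 mg/kg to 30 mg/kg.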

Compound 4, dose for half-maximal effect: 21 mg/kg
Compound 4: middle estimate off by 1.8-fold (0.24 log units), on the low side, within the range that was stated.
By their numbers in this assay, from the lowest: compounds 3, 1, 2 and 4 (each within the scatter of the next, the first and the last beyond it).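

In this assay, for the compounds shown here, the loss of phenyl from the amide-type nitrogen gives the first step beyond the scatter (a 2.6-fold higher number from compound 3 to compound 4 (0.42 log units; beyond the scatter)), so this nitrogen's substituent can shift the dose, though only modestly. Hydrogen in place of benzyl (a 1.3-fold higher number from compound 2 to compound 4 (0.12 log units; within the scatter)) and amino in place of dimethylamino (a 1.3-fold higher number from compound 1 to compound 4 (0.12 log units; within the scatter)) both stay within the scatter, so only compound 3 and compound 4 can be told apart. Nothing available explains this difference.

Still open, going by these compounds, is how a cyclohexyl or pyridyl group on that nitrogen would compare with phenyl.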